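Demethylation on the ketone-side ring of compound 1

The source may report more compounds than this note shows. Statements on the series, on what has been measured and on what is new or still open speak of the compounds shown alone.

Compound 1 `COc1cccc(/C=C/C(=O)c2c(OC)cc(OC)cc2OC)c1` and compound 2 `COc1cc(OC)c(C(=O)/C=C/c2ccc(F)cc2)c(OC)c1` share one core. In a functional assay on HaCaT cells (Homo sapiens), read by fluorescence and BrdU incorporation, with a stated time of 48 h, tested at 25 uM (on this read-out lower numbers stand for a stronger effect and higher numbers for a weaker effect at the one concentration tested), compound 1 gives 0% and compound 2 gives 0.4%, the two numbers within the scatter of each other. Within the data shown here, the only measured step, a number 0.4 percentage points higher from compound 1 to compound 2 (within the scatter), swaps the ring on a double-bonded chain carbon and is within the scatter. Compound 3 `COc1cccc(/C=C/C(=O)c2c(O)cc(OC)cc2OC)c1` differs from compound 1 at another point: hydrogen in place of methyl on an oxygen on an aromatic ring. Among the measured compounds shown here, no measured step touches this oxygen, so the single step gives only a weak sense of the spread. The step of a number 5 percentage points higher from compound 1 to compound 3 (within the scatter) is expected to stay within the scatter. The estimate for compound 3 is 5%, between 0% and 25%.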

Compound 3, a percentage reported as activity, at one concentration (the size of the read-out at that concentration, not a potency): 8%
For compound 3 the middle estimate is 3 percentage points below the measured one; measured number inside the range.
By their numbers in this assay, from the lowest: compounds 1, 2 and 3 (each within the scatter of the next).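

In this assay, methoxy to hydroxy on this oxygen on an aromatic ring gives a number 8 percentage points higher from compound 1 to compound 3 (within the scatter), so this position, like the ring on the chain, shows no change beyond the scatter. At the one concentration tested, the methyl on this oxygen is not needed to keep the read-out low. No available data bear on the reason for this result. Open, going by these compounds, are whether an ethoxy group or an amine at this place keeps the read-out as low, and whether hydroxy in place of methoxy behaves the same with the 4-fluorophenyl of compound 2.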